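This account rests on a few compounds, and the source may have more. Where it says the series, first, only, none or still open, it means among the compounds named here.

Of the compounds shown here, two from this series have been tested in a functional assay on the whole organism for activation, with Mus musculus as the target; on this read-out higher numbers stand for an effect only at larger amounts of compound and lower numbers for an effect already at smaller amounts. Compound 1 `Nc1nc(O)nc2c1nc(O)n2Cc1ccccc1` gives 1 mg/kg in this assay. Going by the values given here, compound 2 `CCCCc1nc(N)c2nc(O)n(Cc3ccccc3)c2n1` gives 0.3 mg/kg in this assay, and it stands as the lower of the two numbers measured so far. Among the compounds with values here, the one step joining these two compounds, butyl in place of hydroxy on an aromatic carbon, gave a 3.3-fold lower number from compound 1 to compound 2 (0.52 log units; beyond the scatter).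

Compound 3 `CCCCCNc1nc(N)c2nc(O)n(Cc3ccccc3)c2n1` has not yet been measured. It differs from compound 2 in one place: pentylamino in place of butyl on an aromatic carbon. The change sits on the same aromatic carbon where the earlier step was made, so that step is the only one that bears on it. Within the data shown here, it showed that this carbon tolerates a change from hydroxy to butyl with a modest improvement, but no measured pair shows what replacing butyl by pentylamino does, and the two groups differ in what they carry. On that basis, no step beyond the scatter is expected from compound 2 to compound 3, no change at the digits printed from compound 2 to compound 3 (within the scatter). Compound 3 is therefore estimated at 0.3 mg/kg in this assay, with a range from 0.1 mg/kg to 1 mg/kg.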

Compound 3, minimum effective dose: 0.3 mg/kg
Beside the measured number, compound 3's estimate shows no gap at the digits printed; the measured number falls inside the stated range.
By their numbers in this assay, from the lowest: compounds 2 and 3 (each within the scatter of the next); then compound 1.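

In this assay, replacing butyl with pentylamino gives no change at the digits printed from compound 2 to compound 3 (within the scatter), so this aromatic carbon between two ring nitrogen atoms accepts a chain joined through nitrogen, with its hydrogen-bond donor and acceptor, without a measurable shift from the chain joined through carbon. Set against hydroxy, pentylamino gives a 3.3-fold lower number from compound 1 to compound 3 (0.52 log units; beyond the scatter), a step of the same size as a 3.3-fold lower number from compound 1 to compound 2 (0.52 log units; beyond the scatter), which shows that the gain over hydroxy at this position is not confined to butyl. No measurement is available to explain why the two chains give matching results.

The compounds shown do not tell how a bare amine, a butoxy chain joined through oxygen, or a longer chain such as octylamino would behave at this carbon. Butyl and pentylamino also differ in both chain length and linking atom, so the contribution of each remains unresolved, and the matching numbers could reflect two separate effects that happen to cancel or neither having any effect at all.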